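Removing the amino group from a purine core: an estimate

The source may report more compounds than this note shows. Statements on the series, on what has been measured and on what is new or still open speak of the compounds shown alone.

Compounds measured so far:
compound 1 `Nc1nc(Cl)c2ncn(Cc3ccccc3CCl)c2n1` — 14500 nM
compound 2 `ClCc1cccc(Cn2cnc3nc(Cl)nc(Cl)c32)c1` — 3800 nM
compound 3 `ClCc1ccccc1Cn1cnc2ncnc(Cl)c21` — 24500 nM

Of the compounds shown here, three sharing a fused core have been tested in a functional assay on SF-268 cells (Homo sapiens) for cytotoxicity, read by sulforhodamine B assay, with a stated time of 48 h; a lower number here means a stronger inhibitor of growth, a higher number a weaker inhibitor of growth. Compound 1 gives 14500 nM in this assay and stands second highest of the three numbers. Its nearest neighbour is compound 3, whose number in this assay is 24500 nM and lies within the scatter of compound 1; the furthest is compound 2, whose 3800 nM sits beyond the scatter, on the lower side.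

The next compound, compound 4 `ClCc1ccccc1Cn1cnc2c(Cl)ncnc21`, is not yet measured. It differs from compound 1 in one place: hydrogen in place of amino on an aromatic carbon. Within the data shown here, no measured pair in this set shows the same change, so its effect cannot be read off directly.

Given that the two otherwise closest compounds, compound 1 and compound 3, lie within the scatter of each other, compound 4 is expected to remain close to compound 1, with the step of a 1.2-fold higher number from compound 1 to compound 4 (0.09 log units; within the scatter) expected to be none beyond the scatter. Compound 4 is therefore estimated at 18000 nM, in the range from 7000 nM to 50000 nM.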

Compound 4, concentration for total growth inhibition: 10900 nM
Compound 4: the middle estimate sits 1.7-fold (0.22 log units) above what was measured, within the range that was stated.
By their numbers in this assay, from the lowest: compound 2; then compounds 4, 1 and 3 (each within the scatter of the next, the first and the last beyond it).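

In this assay, among these compounds, the first direct reading of hydrogen in place of amino on this aromatic carbon, between two ring nitrogen atoms, is a 1.3-fold lower number from compound 1 to compound 4 (0.12 log units; within the scatter) and so stays within the scatter. For this one pair, the amino group, with its hydrogen-bond donor and acceptor, can leave this position without a step beyond the scatter in the growth-inhibition read-out. Nothing available explains this result, so no cause can be assigned to it.

As far as these compounds go, what remains open is whether another group at this position, such as methylamino, hydroxyl or methoxy, would give a step beyond the scatter. From the compounds shown here alone, it is also open whether the same exchange of amino for hydrogen would give a similar step on another compound of this kind.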